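Chloro on the Fused Ring: Expected Effect on Growth Inhibition

A few compounds are considered here, and "the series" means these few. Any claim that something is new, unique, unknown or untested is made for them only; others in the source may bear on it.

Compound 1 `O=S(=O)(/C=C/c1ccc(F)cc1)Cc1ccc(Nc2ncnc3ccccc23)cc1` gives 10 nM in a functional assay on ACHN cells (Homo sapiens); on this read-out higher numbers stand for weaker inhibition of growth and lower numbers for stronger inhibition of growth.
Compound 2 `O=S(=O)(/C=C/c1ccc(Cl)cc1Cl)Cc1ccc(Nc2ncnc3ccccc23)cc1` gives 100 nM in this assay.
Compound 3 `O=S(=O)(/C=C/c1ccc(F)cc1Cl)Cc1ccc(Nc2ncnc3ccccc23)cc1` gives 73000 nM in this assay.

Compound 4 `O=S(=O)(/C=C/c1ccc(Cl)cc1Cl)Cc1ccc(Nc2ncnc3cc(Cl)ccc23)cc1` has not been measured. The cores of compound 1 and compound 2 differ by 2,4-dichlorophenyl in place of 4-fluorophenyl on a double-bonded chain carbon bound to a double-bonded chain carbon, which gave a 10-fold higher number from compound 1 to compound 2 (1.00 log units; beyond the scatter). The change from compound 2 to compound 4 is chloro in place of hydrogen on an aromatic carbon. The same kind of change, from compound 1 to compound 3, is chloro in place of hydrogen on an aromatic carbon, and it gave a 7300-fold higher number from compound 1 to compound 3 (3.86 log units; beyond the scatter). The two places are not alike: in one case the chloro enters ortho to a large group and meta to a fluoro group on an unfused ring, in the other on a ring that is part of a fused system, meta to a fused ring and para to a fused ring. With the place so different, the large step is a weak guide. For compound 4 the expected step is a 2.0-fold higher number from compound 2 to compound 4 (0.30 log units; within the scatter), and the estimate for compound 4 is 200 nM, between 30 nM and 2000 nM.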

Compound 4, concentration for 50% growth inhibition: 8000 nM
Beside the measured number, compound 4's estimate is 40-fold (1.60 log units) below it, outside the stated range (above it).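

Putting chloro in place of hydrogen raised the number in this assay on both cores, and the new case gives an 80-fold higher number from compound 2 to compound 4 (1.90 log units; beyond the scatter), so the direction of the change carried over from one core to the other. The size did not carry over, and the two steps also sit at different places, so the effect of the core cannot be separated from the effect of the place: the same change on two cores in this assay, a 7300-fold higher number (3.86 log units; beyond the scatter) from compound 1 to compound 3 and an 80-fold higher number (1.90 log units; beyond the scatter) from compound 2 to compound 4, 91-fold (1.96 log units) apart, beyond the scatter of two such steps. A step from one core is therefore a poor guide to its size on another, and these pairs do not show why the two steps differ.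

The compounds shown leave open what chloro does at this same place on the core of compound 1. They also leave open whether an amine or a methoxy group there would act as chloro does.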